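This account rests on a few compounds, and the source may have more. Where it says the series, first, only, none or still open, it means among the compounds named here.

Working notes on the series. For the measured compounds named here, in a functional assay on KB cells (Homo sapiens) for cytotoxicity, read by colorimetric assay and neutral red uptake, with a stated time of 72 h (a lower number here means a stronger inhibitor, a higher number a weaker inhibitor), compound 1 `CO[C@@H](C(=O)N[C@H]1CCCCNC1=O)[C@H](O)[C@@H](O)[C@H](O)/C=C/C(C)(C)C` gives 21000 nM, the only actual number so far. Compound 2 `CO[C@@H](C(=O)N[C@H]1CCCCNC1=O)[C@@H]1OC(C)(C)O[C@H](/C=C/C(C)(C)C)[C@@H]1O` gives > 150000 nM, which is a limit and not a number. Compound 3 `CO[C@@H](C(=O)N[C@H]1CC[C@@H](O)CNC1=O)[C@H](O)[C@@H](O)[C@H](O)/C=C/C(C)(C)C` differs from compound 1 by hydroxy in place of hydrogen on a saturated ring carbon, turning 2-oxoazepan-3-yl into 6-hydroxy-2-oxoazepan-3-yl. Going by the values given here, no measured step covers this change, so the only anchor is compound 1 at 21000 nM. In this assay, a shift no larger than the usual scatter is expected, with an estimated 1.8-fold lower number from compound 1 to compound 3 (0.24 log units; within the scatter). For compound 3 the estimate is 12000 nM, with an expected range of 2500 nM to 60000 nM.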

Compound 3, half-maximal inhibitory concentration: 62600 nM
Compound 3: middle estimate off by 5.2-fold (0.72 log units), on the low side; measured number outside the range, above it.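

On the seven-membered ring, the saturated carbon two ring bonds from the ring nitrogen is not silent in this assay: hydroxy in place of hydrogen there gives a 3.0-fold higher number from compound 1 to compound 3 (0.47 log units; beyond the scatter), so compound 3 is the weaker of the pair. For the compounds shown here, this is the only reading for this position, and it shows that the change moves the number beyond the scatter. Nothing at hand bears on the cause of this step.

Whether the shift belongs to hydroxy itself remains open, since a methoxy, a fluorine or an amine at this carbon is not among the compounds shown. The opposite configuration of the hydroxy carbon is also absent from them.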